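Ester Variation on a Shared Core

The compounds below may be only part of what the source reports. "The series", "measured", "known", "first", "only" and "open" are said of these compounds alone.

Measured in a functional assay on the whole organism (strain Sprague-Dawley CD) for inhibition, with Rattus norvegicus as the target, read by paw edema, at a dose of 30 mg/kg by the intraperitoneal route; on this read-out higher numbers stand for a stronger effect at the one dose given and lower numbers for a weaker effect:
Compound 1 `CC(C)OC(=O)C(=O)Nc1cccccc1=O` gives 96%.
Compound 2 `CC(C)(C)OC(=O)C(=O)Nc1cccccc1=O` gives 79%.
Compound 3 `O=C(O)COC(=O)C(=O)Nc1cccccc1=O` gives 93%.

Compound 3 stands second highest of the three numbers; its nearest neighbour is compound 1, with a number 3 percentage points lower from compound 1 to compound 3 (within the scatter), and the furthest is compound 2, with a number 14 percentage points higher from compound 2 to compound 3 (beyond the scatter). Compound 4 `O=C(Nc1cccccc1=O)C(=O)Oc1ccccc1` differs from compound 3 in one place: phenyl in place of carboxymethyl on an oxygen next to a carbonyl group. The steps that change this oxygen-bound group, a number 3 percentage points lower from compound 1 to compound 3 (within the scatter) and a number 14 percentage points higher from compound 2 to compound 3 (beyond the scatter), were within the scatter or modest, and a number 17 percentage points lower from compound 1 to compound 2 (beyond the scatter) was modest too. Within the data shown here, no measured step brings in an aromatic ring here, so a step in this assay of at most modest size is expected, with no firm direction. For compound 4 the expected step is a number 5 percentage points lower from compound 3 to compound 4 (within the scatter), giving an estimate of 88% with a range from 68% to 100%.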

Compound 4, a percentage reported as inhibition, in the whole organism at one dose (the size of the read-out at that dose, not a potency): 73%
Beside the measured number, compound 4's estimate is 15 percentage points above it; the range from low to high includes it.
By their numbers in this assay, from the lowest: compounds 4 and 2 (each within the scatter of the next); then compounds 3 and 1 (each within the scatter of the next).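

Phenyl is the first aromatic ring on an oxygen next to a carbonyl group in this series, and in this assay it sits clearly under two earlier groups (a number 20 percentage points lower from compound 3 to compound 4 (beyond the scatter); a number 23 percentage points lower from compound 1 to compound 4 (beyond the scatter)). Against tert-butyl it shows no clear difference (a number 6 percentage points lower from compound 2 to compound 4 (within the scatter)), so a ring here does no more than match the lowest earlier compound. No measured evidence accounts for these differences. The compounds shown leave open how benzyl, which sets a methylene before the ring, or a longer chain such as n-butyl would read at this oxygen.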